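Urea-linked pyrazole series: methoxy to hydroxy on the aryl

The source may hold more compounds than are shown below. What is called first, only, known or untested is meant among the compounds shown, and "the series" means these compounds.

Compound 1 `O=C(Nc1cccc(-n2cc(-c3ccncc3)c(-c3ccc(Cl)c(O)c3)n2)c1)Nc1cccc(C(F)(F)F)c1` gives 12000 nM in a functional assay on RXF 393 cells (Homo sapiens) for inhibition, read by sulforhodamine B assay, with a stated time of 48 h; on this read-out higher numbers stand for weaker inhibition of growth and lower numbers for stronger inhibition of growth. Compound 2 `O=C(Nc1cccc(-n2cc(-c3ccncc3)c(-c3ccc(Cl)c(O)c3)n2)c1)Nc1ccc(Cl)c(Cl)c1` gives 6400 nM in this assay, and compound 3 `COc1cc(-c2nn(-c3cccc(NC(=O)Nc4ccc(Cl)c(C(F)(F)F)c4)c3)cc2-c2ccncc2)ccc1Cl` gives 6290 nM. All three numbers lie within the scatter of one another, so compound 3 is not set apart from compound 2 or compound 1. Going by the values given here, the one measured step, a 1.9-fold lower number from compound 1 to compound 2 (0.27 log units; within the scatter), concerns the aryl on the urea nitrogen and not the oxygen substituent. Compound 4 `O=C(Nc1cccc(-n2cc(-c3ccncc3)c(-c3ccc(Cl)c(O)c3)n2)c1)Nc1ccc(Cl)c(C(F)(F)F)c1` differs from compound 3 by hydrogen in place of methyl on an oxygen on an aromatic ring. Among the compounds with values here, no measured pair covers this change, so nothing shows which way it moves; the expectation is a step no larger than the scatter, with a 1.0-fold higher number from compound 3 to compound 4 (0.01 log units; within the scatter). Compound 4 is therefore estimated at 6500 nM, with a range from 3000 nM to 14000 nM.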

Compound 4, concentration for total growth inhibition: 1670 nM
Estimate against measurement, compound 4: 3.9-fold (0.59 log units) above; the measured number lies below the stated range.
By their numbers in this assay, from the lowest: compound 4; then compounds 3, 2 and 1 (each within the scatter of the next).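

In this assay, going by these compounds alone, the oxygen on the aromatic ring proves sensitive to substitution: hydrogen in place of methyl gives a 3.8-fold lower number from compound 3 to compound 4 (0.58 log units; beyond the scatter), the first reading at this position. With the hydroxy kept, the urea aryl also matters, with trifluoromethyl in place of chloro giving a 3.8-fold lower number from compound 2 to compound 4 (0.58 log units; beyond the scatter) and chloro in place of hydrogen giving a 7.2-fold lower number from compound 1 to compound 4 (0.86 log units; beyond the scatter). No available evidence accounts for these steps.

On these data alone, the methoxy to hydroxy change is read on the urea aryl of compound 4 alone, so its effect with other urea aryls remains open. Also open, as far as these compounds go, is how an amine or an ethoxy group would compare with hydroxy on this aromatic carbon.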